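This account rests on a few compounds, and the source may have more. Where it says the series, first, only, none or still open, it means among the compounds named here.

Measured so far in an assay on isolated protein for inhibition of histone deacetylase HD1B (Zea mays); a lower number here means a stronger inhibitor, a higher number a weaker inhibitor:
Compound 1 `Cn1cc(/C=C/C(=O)c2ccccc2Cl)cc1/C=C/C(=O)NO` gives 1600 nM.
Compound 2 `Cn1cc(/C=C/C(=O)c2ccc(Cl)cc2)cc1/C=C/C(=O)NO` gives 29400 nM.
Compound 3 `Cc1cccc(C(=O)/C=C/c2cc(/C=C/C(=O)NO)n(C)c2)c1` gives 2500 nM.

On these numbers compound 3 stands second highest of the three. Its nearest neighbour is compound 1, with a 1.6-fold higher number from compound 1 to compound 3 (0.19 log units; within the scatter), a step within the scatter; furthest away is compound 2, with a 12-fold lower number from compound 2 to compound 3 (1.07 log units; beyond the scatter), a step beyond it.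

Compound 4 `Cn1cc(/C=C/C(=O)c2cccs2)cc1/C=C/C(=O)NO` has not been measured. It differs from compound 3 in one place: thiophen-2-yl in place of 3-methylphenyl on a carbonyl carbon. The two measured steps that touch this position both end at compound 3 and both exchange one six-membered aromatic ring of carbon only for another, namely a 1.6-fold higher number from compound 1 to compound 3 (0.19 log units; within the scatter) and a 12-fold lower number from compound 2 to compound 3 (1.07 log units; beyond the scatter). For the measured compounds named here, neither exchanges the ring type, so no measured step bears directly on the move to a five-membered aromatic ring with one hetero atom. Numbers at this position do vary widely, as an 18-fold higher number from compound 1 to compound 2 (1.26 log units; beyond the scatter) shows, but the direction for thiophen-2-yl cannot be read from these three compounds. The expectation is therefore a number close to compound 3 with a wide range. Compound 4 is estimated at 3000 nM, between 900 nM and 10000 nM. The expected step is a 1.2-fold higher number from compound 3 to compound 4 (0.08 log units; within the scatter), not beyond the scatter.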

Compound 4, half-maximal inhibitory concentration: 25800 nM
Beside the measured number, compound 4's estimate is 8.6-fold (0.93 log units) below it, outside the stated range (above it).
By their numbers in this assay, from the lowest: compounds 1 and 3 (each within the scatter of the next); then compounds 4 and 2 (each within the scatter of the next).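

In this assay, for the compounds shown here, the first ring change at this position, to a five-membered aromatic ring with one hetero atom, carries a large penalty: a 10-fold higher number from compound 3 to compound 4 (1.01 log units; beyond the scatter), and a 16-fold higher number from compound 1 to compound 4 (1.21 log units; beyond the scatter). A large rise in the number on this carbonyl carbon is therefore no longer confined to 4-chlorophenyl, since thiophen-2-yl cannot be told apart from that group, with a 1.1-fold lower number from compound 2 to compound 4 (0.06 log units; within the scatter); among the four compounds, only 2-chlorophenyl and 3-methylphenyl give the low numbers. No measurement is available to explain this split.

As far as these compounds go, with a single five-membered ring, it remains open whether furan-2-yl, with oxygen in place of sulfur, or thiophen-3-yl would sit with compound 4 or with compounds 1 and 3. Also open, from the compounds shown here alone, is how an unsubstituted phenyl would compare, and whether a phenyl bearing an amine or a carboxylic acid would keep the low numbers of compounds 1 and 3.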